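Halogen swap on the shared core: iodo to bromo

The source may hold more compounds than are shown below. What is called first, only, known or untested is meant among the compounds shown, and "the series" means these compounds.

For the measured compounds named here, compound 1 `O=C1[C@@]2(CO)C=C(I)C(CC2c2ccccc2)[C@]12CO2` is the only member of the series with a numerical read-out in an ADME assay on Huh-7 cells (Homo sapiens) for cytotoxicity; on this read-out higher numbers stand for lower toxicity in this test and lower numbers for higher toxicity in this test; in this assay compound 1 gives 27100 nM. Compound 2 `CO[C@]12C=C(Br)C(CC1c1cccc(C)c1)[C@]1(CO1)C2=O` is recorded in this assay only as a limit, > 50000 nM. Compound 3 `O=C1C2C=C(I)C(CC2OCCCCO)[C@]12CO2` likewise reaches only a limit in this assay, > 50000 nM. Going by the values given here, two of the three results thus sit at the limit of > 50000 nM in this assay, at which 2 of the 3 values shown sit, so compound 1 stands as the sole point with a fixed position, and no pair of measured compounds differs in a single place, which leaves no measured step to lean on.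

Compound 4 `O=C1[C@@]2(CO)C=C(Br)C(CC2c2ccccc2)[C@]12CO2` is the next candidate for this assay. Relative to compound 1 the change is bromo in place of iodo on a double-bonded ring carbon. The rest of the core, the hydroxymethyl group and the phenyl-bearing ring remain as in compound 1.

The expectation is that the step from compound 1 to compound 4 in this assay will be small, no larger than the usual scatter, estimated as a 1.3-fold higher number from compound 1 to compound 4 (0.11 log units; within the scatter). Compound 4 is therefore expected to read 35000 nM, within a range of 15000 nM to 80000 nM, with a fair chance that this assay again returns only a limit.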

Compound 4, half-maximal cytotoxic concentration: > 50000 nM
Compound 4: a limit, no number; the forecaster's own chance of this, stated with the estimate: 35%; middle value at least 1.4-fold (0.15 log units) away from the limit.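

Compound 4 is recorded in this assay only as a limit, > 50000 nM. Bromo in place of iodo on a double-bonded ring carbon gives an at least 1.8-fold higher number from compound 1 to compound 4 (0.26 log units; that floor lies within the scatter), which is the first step in the series that can be read, with the hydroxymethyl group and the rest of the core of compound 1 left unchanged, though it fixes only a floor and not a size. On this position the change therefore cannot be told apart from repeated-measurement scatter, and the true distance between the iodo and bromo compounds stays unknown, with most of the series now resting on one limit: the limit of > 50000 nM in this assay, at which 3 of the 4 values shown sit.

Still open, on these data alone, is what a chloro group, an amine or a carboxylic acid on this double-bonded ring carbon would read in this assay, and whether any of them would give a number rather than another limit. For the compounds shown here, also open is whether the same bromo in place of iodo change would read alike on a core carrying other groups, as compound 1 remains the only compound with a number, 27100 nM, and this single step is the only one available at this position.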